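Replacing the piperidin-1-yl group of compound 2

The source may hold more compounds than are shown below. What is called first, only, known or untested is meant among the compounds shown, and "the series" means these compounds.

In a functional assay on DU-145 cells (Homo sapiens) for antiproliferative activity, read by sulforhodamine B assay, with a stated time of 3 days (on this read-out higher numbers stand for weaker inhibition of growth and lower numbers for stronger inhibition of growth), compound 1 (`COc1ccc(N2CCN(C)CC2)cc1Nc1ncc(F)c(Nc2ccc(F)cc2)n1`) gives 910 nM and compound 2 (`O=C(c1cccc(Nc2ncc(F)c(Nc3ccc(F)cc3)n2)c1)N1CCCCC1`) gives 13000 nM as the higher number of the two, a gap beyond the usual scatter. That places compound 2 as the weaker inhibitor of growth in this pair. Compound 3 (`Cn1ccnc1NC(=O)c1cccc(Nc2ncc(F)c(Nc3ccc(F)cc3)n2)c1`) carries (1-methyl-1H-imidazol-2-yl)amino in place of piperidin-1-yl on a carbonyl carbon. Within the data shown here, no measured pair shows a single change of this kind, so the expectation is loose. In this assay a moderate step towards stronger inhibition is expected (a 3.7-fold lower number from compound 2 to compound 3 (0.57 log units; beyond the scatter)). For compound 3 the estimated value is 3500 nM (900 nM to 13000 nM).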

Compound 3, concentration for 50% growth inhibition: 15100 nM
For compound 3 the middle estimate is 4.3-fold (0.63 log units) below the measured one; measured number above the stated range.
By their numbers in this assay, from the lowest: compound 1; then compounds 2 and 3 (each within the scatter of the next).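

In this assay, putting (1-methyl-1H-imidazol-2-yl)amino in place of piperidin-1-yl on the carbonyl carbon gives a 1.2-fold higher number from compound 2 to compound 3 (0.07 log units; within the scatter). At this position, then, a five-membered aromatic ring carrying a hydrogen-bond donor and acceptors and a six-membered non-aromatic ring without them give numbers that cannot be told apart. No available evidence bears on this result.

On these data alone, whether a morpholin-4-yl group or a simple amine such as dimethylamino on the same carbonyl carbon would give a number beyond the scatter remains open.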